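A few compounds are considered here, and "the series" means these few. Any claim that something is new, unique, unknown or untested is made for them only; others in the source may bear on it.

Values so far in a physicochemical assay for lipophilicity, read by HPLC, at pH 7.5; on this read-out lower numbers stand for lower lipophilicity and higher numbers for higher lipophilicity

- compound 1 `CC[C@@H](Nc1c(C#N)c(-c2ccc(-c3ccccc3F)cc2)nc2cnccc12)C(N)=O` gives 2.7
- compound 2 `N#Cc1c(-c2ccc(Br)cc2)nc2cnccc2c1NCC(N)=O` gives 1.9
- compound 3 `CC[C@@H](Nc1c(C#N)c(-c2ccc(-c3cccc(C)c3F)cc2)nc2cnccc12)C(N)=O` gives 3

Compound 2 has the lowest number of the three, and it stands clearly apart from both compound 1 and compound 3. The next compound to consider is compound 4 `CC[C@@H](Nc1c(C#N)c(-c2ccc(Br)cc2)nc2cnccc12)C(=O)O`, which has not yet been measured in this assay. The change from compound 2 is 1-carboxypropyl in place of carbamoylmethyl on a nitrogen on an aromatic ring, which means 1-carboxypropyl in place of carbamoylmethyl on a nitrogen on an aromatic ring. Among the measured compounds shown here, the only measured step offers little guidance. It is a number 0.30 log units higher from compound 1 to compound 3 (within the scatter), and it concerns methyl in place of hydrogen on an aromatic carbon, not this chain. For the measured compounds named here, no measured pair exchanges these two chains, so the expectation rests on the structural change alone and its size is uncertain. A fall beyond the scatter is expected, and the estimated step is a number 1.10 log units lower from compound 2 to compound 4 (beyond the scatter) in this read-out. For compound 4 the expected value is 0.8, with an estimated range from 0 to 1.6.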

Compound 4, distribution coefficient: 1.6
For compound 4 the middle estimate is 0.80 log units below the measured one; the range from low to high includes it.
By their numbers in this assay, from the lowest: compounds 4 and 2 (each within the scatter of the next); then compounds 1 and 3 (each within the scatter of the next).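

At the nitrogen on the aromatic ring, the first step shown for this position in this assay is a number 0.30 log units lower from compound 2 to compound 4 (within the scatter). Replacing carbamoylmethyl with 1-carboxypropyl therefore leaves the two compounds indistinguishable on this read-out, even though the entering chain is larger, ends in a different group and has a defined stereocentre, while its hydrogen-bond donor and acceptor counts match those of the chain it replaces. The data shown offer no measured explanation for this outcome.

The chain length and the end group change together in this single step, so their separate contributions cannot be read from it. A carboxymethyl chain on the same nitrogen would separate them for the acid, and a chain ending in an amine would extend the comparison to another end group, leaving both questions open here.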